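Chloro to bromo at the limit of growth inhibition

The source may report more compounds than this note shows. Statements on the series, on what has been measured and on what is new or still open speak of the compounds shown alone.

In a functional assay on DU-145 cells (Homo sapiens) for inhibition, read by trypan blue exclusion, with a stated time of 96 h (on this read-out lower numbers stand for stronger inhibition of growth and higher numbers for weaker inhibition of growth), compound 1 `CN(C)c1ccc(/C=C(/Sc2ccccc2Br)C(=O)c2ccc(Br)cc2)cc1` gives > 100000 nM and this is a limit of the assay, not a number. Compound 2 `O=C(/C(=C\c1c(O)cc(O)cc1O)Sc1ccccc1Br)c1ccc(Cl)cc1` gives > 100000 nM and this too is a limit. Among the measured compounds shown here, the series so far stands at the limit of > 100000 nM in this assay, at which 2 of the 2 values shown sit, and compound 2 has no number of its own, only that limit. Compound 3 `O=C(/C(=C\c1c(O)cc(O)cc1O)Sc1ccccc1Br)c1ccc(Br)cc1` has bromo in place of chloro on an aromatic carbon, para to a large group (bromo in place of chloro on an aromatic carbon). For the measured compounds named here, no measured pair sizes such a change, so no step beyond the scatter is expected in this assay in either direction. The expected step is a number no higher from compound 2 to compound 3 (the limit leaves the size open) and a further limit is the likeliest report. The estimate for compound 3 is 100000 nM with an expected range from 30000 nM to 300000 nM in this assay.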

Compound 3, concentration for 50% growth inhibition: > 100000 nM
Compound 3 ended at the assay's limit (the forecaster's own chance of this, stated with the estimate: 80%); the middle value sits exactly at the limit.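

No step can be read from compound 2 to compound 3 or from compound 1 to compound 3 in this assay, because each value is a limit and not a number: the limit of > 100000 nM in this assay, at which 3 of the 3 values shown sit.

The compounds shown leave open how they rank in growth inhibition and whether bromo in place of chloro changes it.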